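The source may report more compounds than this note shows. Statements on the series, on what has been measured and on what is new or still open speak of the compounds shown alone.

Measured so far in an in vitro functional assay on HEK293-A cells for positive allosteric modulation of metabotropic glutamate receptor 5 (Homo sapiens), read by FLIPR and calcium flux; on this read-out higher numbers stand for an effect only at larger amounts of compound and lower numbers for an effect already at smaller amounts:

Compound 1, `O=C1CC(c2nc(-c3cccc(Cl)c3)no2)CN1c1ccc(Cl)cc1`, gives 140 nM.
Compound 2, `COc1cccc(-c2noc(C3CC(=O)N(c4ccc(Cl)cc4)C3)n2)c1`, gives 4800 nM.
Compound 3, `Cc1cccc(-c2noc(C3CC(=O)N(c4ccc(Cl)cc4)C3)n2)n1`, gives only a limit of the assay, > 10000 nM.

Compound 1 holds the lowest of the two numbers. Its nearest neighbour is compound 2, reached by a 34-fold higher number from compound 1 to compound 2 (1.54 log units; beyond the scatter), where methoxy replaces chloro on an aromatic carbon. Compound 3 sits at the limit of > 10000 nM in this assay, at which 1 of the 3 values shown sits, so the step of an at least 71-fold higher number from compound 1 to compound 3 (1.85 log units; beyond the scatter), with 6-methylpyridin-2-yl in place of 3-chlorophenyl, can only be given as a lower bound. Likewise an at least 2.0-fold higher number from compound 2 to compound 3 (0.31 log units; beyond the scatter) is a lower bound.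

Compound 4, `Cc1ccc(N2CC(c3nc(-c4cccc(Cl)c4)no3)CC2=O)cc1`, has not yet been measured. It differs from compound 1 by methyl in place of chloro on an aromatic carbon. For the measured compounds named here, none of the measured steps touches this ring: all three alter the aromatic group on the other side of the shared core, and they leave the ring carrying the chloro-to-methyl exchange untouched. There is therefore no direct guide from the data, and the expectation rests on the small size of the change itself, one heavy atom swapped for one heavy atom without new donors or acceptors. The expected step is a 2.1-fold higher number from compound 1 to compound 4 (0.33 log units; beyond the scatter), a small drift rather than a large jump, in either direction within the scatter or modestly beyond it. Compound 4 is thus estimated at 300 nM, within a range from 80 nM to 1500 nM.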

Compound 4, half-maximal effective concentration: 630 nM
Compound 4: the middle estimate sits 2.1-fold (0.32 log units) below what was measured; low and high end bracket the measured number.
By their numbers in this assay, from the lowest: compound 1; then compound 4; then compound 2. At a limit, above all of these: compound 3.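

In this assay, for the compounds shown here, on the 4-chlorophenyl ring that no earlier step touched, 4-methylphenyl in its place gives a 4.5-fold higher number from compound 1 to compound 4 (0.65 log units; beyond the scatter), so this position is not indifferent to what it carries, even when one heavy atom simply replaces another and no hydrogen-bond donor or acceptor enters or leaves. Going by these compounds alone, the step is modest, whereas changes on the other aromatic group, such as a 34-fold higher number from compound 1 to compound 2 (1.54 log units; beyond the scatter), are large, so within these few compounds the 4-chlorophenyl end tolerates its one change better than the other end tolerates its changes. Nothing measured here accounts for the size of this step.

With only chloro and methyl shown at this position, it remains open how a plain hydrogen, a fluoro group, a hydroxyl, an amine or a carboxylic acid would behave there, and whether chloro is the best choice or merely the better of two. Also open, going by these compounds, is whether the same exchange of chloro for methyl on the 3-chlorophenyl ring would give a step of similar size.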